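Swapping Methoxy for Phenyl on Two Related Cores

The source may hold more compounds than are shown below. What is called first, only, known or untested is meant among the compounds shown, and "the series" means these compounds.

The measured compounds:
Compound 1 `COc1ccc(NC(=O)COc2c(-c3ccccc3)oc3ccccc3c2=O)cc1` gives 5480 nM in a functional assay on NPC-TW01 cells (Homo sapiens) for antiproliferative activity, read by MTT assay, with a stated time of 72 h; on this read-out higher numbers stand for weaker inhibition of growth and lower numbers for stronger inhibition of growth.
Compound 2 `O=C(COc1c(-c2ccccc2)oc2ccccc2c1=O)Nc1ccc(-c2ccccc2)cc1` gives in this assay > 10000 nM, which is a limit of the assay rather than a number.
Compound 3 `COc1ccc(NC(=O)COc2ccc3oc(-c4ccccc4)cc(=O)c3c2)cc1` gives in this assay 710 nM.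

Compound 1 and compound 2 share one core and differ in a single place: phenyl in place of methoxy on an aromatic carbon. The step is an at least 1.8-fold higher number from compound 1 to compound 2 (0.26 log units; that floor lies within the scatter), and because the limit of > 10000 nM in this assay, at which 1 of the 3 values shown sits, the true size of that step cannot be fixed, only its floor. Compound 3 has the same atoms as compound 1, joined differently; the difference between the two cores is not broken down here. Compound 3 sits well below compound 1 in this assay, with a gap that lies beyond the scatter.

Compound 4 `O=C(COc1ccc2oc(-c3ccccc3)cc(=O)c2c1)Nc1ccc(-c2ccccc2)cc1` has not yet been measured. It stands to compound 3 exactly as compound 2 stands to compound 1: phenyl in place of methoxy on an aromatic carbon, the same change on the second core. Compound 4 is expected to give a higher number than compound 3, a step estimated at a 3.9-fold higher number from compound 3 to compound 4 (0.60 log units; beyond the scatter), resting on the step of an at least 1.8-fold higher number from compound 1 to compound 2 (0.26 log units; that floor lies within the scatter) seen on the first core. Since only a floor is known for that earlier step, the expectation for compound 4 is wide, with an estimate of 2800 nM and a range from 1000 nM to 9000 nM.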

Compound 4, concentration for 50% growth inhibition: 640 nM
The estimate for compound 4 lay 4.4-fold (0.64 log units) above the measured number; the whole stated range lies above it.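

In this assay, putting phenyl in place of methoxy on the second core gives a 1.1-fold lower number from compound 3 to compound 4 (0.05 log units; within the scatter), so compound 3 and compound 4 cannot be told apart on this read-out, and on this core the larger group on the aromatic carbon, para to a large group, is tolerated without a measurable change in growth inhibition. Set beside the first core, this does not show that the change carries across in the same way, nor that the two cores answer to it differently: the same change on two cores in this assay, an at least 1.8-fold higher number (0.26 log units; that floor lies within the scatter) from compound 1 to compound 2 and a 1.1-fold lower number (0.05 log units; within the scatter) from compound 3 to compound 4; the limit leaves it open whether they differ The first step stays a floor and not a size, so the series offers one readable step and one open one, and a rule for moving this change from core to core cannot be drawn from them, because of this: the limit of > 10000 nM in this assay, at which 1 of the 4 values shown sits.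

The compounds shown leave open how the second core would respond at the same place to other groups, such as a chlorine, an amine or a carboxylic acid, and whether such groups would separate the two cores more clearly than phenyl and methoxy do. They also leave open whether the result for compound 3 and compound 4 would hold on cell lines other than the one tested here.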